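Swapping Ethoxy for Methylsulfanyl on the Same Ring Carbon

The source may report more compounds than this note shows. Statements on the series, on what has been measured and on what is new or still open speak of the compounds shown alone.

Of the compounds shown here, three built on one shared core have been tested in a functional assay on MCF7 cells (Homo sapiens) for antiproliferative activity, read by MTT assay, with a stated time of 72 h; a lower number here means a stronger inhibitor, a higher number a weaker inhibitor. Compound 1 `COc1ccccc1-c1ncnn1-c1cc(OC)c(OC)c(OC)c1` gives > 10000 nM in this assay, which is a limit of the method rather than a number (the limit of > 10000 nM in this assay, at which 1 of the 3 values shown sits). Compound 2 `COc1ccc(-c2ncnn2-c2cc(OC)c(OC)c(OC)c2)cc1` gives 360 nM in this assay, a change of an at least 27-fold lower number from compound 1 to compound 2 (1.44 log units; beyond the scatter). Compound 3 `CCOc1ccc(-c2ncnn2-c2cc(OC)c(OC)c(OC)c2)cc1` gives 50 nM in this assay, after a step of a 7.2-fold lower number from compound 2 to compound 3 (0.86 log units; beyond the scatter). Among the compounds with values here, of the two numbers in hand, compound 3 carries the lowest, with compound 2 its only numbered neighbour.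

Compound 4 `COc1cc(-n2ncnc2-c2ccc(SC)cc2)cc(OC)c1OC` differs from compound 3 in a single place: methylsulfanyl in place of ethoxy on an aromatic carbon. Neither measured step bears directly on this exchange: one replaced 2-methoxyphenyl with 4-methoxyphenyl, the other added a methyl to a chain carbon bound to an oxygen. Both groups in the present swap are small, uncharged and without a ring, so no step beyond the scatter is expected. Compound 4 is therefore estimated at 80 nM in this assay, between 20 nM and 400 nM. That estimate corresponds to an expected step of a 1.6-fold higher number from compound 3 to compound 4 (0.20 log units; within the scatter).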

Compound 4, half-maximal inhibitory concentration: 390 nM
Beside the measured number, compound 4's estimate is 4.9-fold (0.69 log units) below it; low and high end bracket the measured number.
By their numbers in this assay, from the lowest: compound 3; then compounds 2 and 4 (each within the scatter of the next). At a limit, above all of these: compound 1.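

In this assay, the exchange of ethoxy for methylsulfanyl on this ring carbon is not a neutral one: a 7.8-fold higher number from compound 3 to compound 4 (0.89 log units; beyond the scatter). Methylsulfanyl and methoxy cannot be told apart here, with a 1.1-fold higher number from compound 2 to compound 4 (0.03 log units; within the scatter), so among the three groups tested on this carbon, ethoxy alone stands out, and it does so with a lower number than either of the others. The large step from the 2-methoxyphenyl compound also holds for methylsulfanyl, an at least 25-fold lower number from compound 1 to compound 4 (1.40 log units; beyond the scatter), although it starts from a limit rather than a number: the limit of > 10000 nM in this assay, at which 1 of the 4 values shown sits.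

The compounds shown do not tell why ethoxy differs from the other two groups. On these data alone, it also remains open whether a longer chain such as propoxy, or an amine, on the same carbon would follow ethoxy or methylsulfanyl.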